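The compounds below may be only part of what the source reports. "The series", "measured", "known", "first", "only" and "open" are said of these compounds alone.

Compound 3 `N#CC1=C(N)Oc2c(N)cc3nc4ccccc4nc3c2C12C(=O)N(Cc1cnnn1-c1ccccc1Cl)c1ccccc12` is one of three compounds whose results are known in a functional assay on HCT-116 cells (Homo sapiens) for antiproliferative activity, read by MTT assay, with a stated time of 48 h; on this read-out lower numbers stand for stronger inhibition and higher numbers for weaker inhibition. In this assay compound 3 gives a limit of the assay, > 50000 nM, rather than a number. Compound 1 `N#CC1=C(N)Oc2c(c3nc4ccccc4nc3c3ccccc23)C12C(=O)N(Cc1cnnn1-c1cccc(Br)c1)c1ccccc12` also gives only a limit in this assay, > 50000 nM. Compound 2 `CCOc1ccccc1-n1nncc1CN1C(=O)C2(C(C#N)=C(N)Oc3c2c2nc4ccccc4nc2c2ccccc32)c2ccccc21` stands at a limit in this assay as well, > 50000 nM. Between the first two lies a step that the two limits leave unreadable from compound 1 to compound 2. All three values sit at the limit of > 50000 nM in this assay, at which 3 of the 3 values shown sit.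

Compound 4 `Cc1ccc(-n2nncc2CN2C(=O)C3(C(C#N)=C(N)Oc4c(N)cc5nc6ccccc6nc5c43)c3ccccc32)cc1C` differs from compound 3 in one place: 3,4-dimethylphenyl in place of 2-chlorophenyl on an aromatic nitrogen. Within the data shown here, no measured step involves the group that changes here, and the single step that is known is unreadable, so the data give no size for a step in this assay and show only that every value so far is a limit. Compound 4 is expected to give 50000 nM in this assay, most likely again as a limit, with a range from 20000 nM to 150000 nM. The expected change is estimated as a number no higher from compound 3 to compound 4 (the limit leaves the size open), nothing beyond the scatter.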

Compound 4, half-maximal inhibitory concentration: > 50000 nM
Compound 4: only a limit was reported; the forecaster's own chance of this, stated with the estimate: 80%; the middle value sits exactly at the limit.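

Compound 3 and compound 4 both stop at a limit in this assay and so the step between them cannot be read. The compounds shown leave open whether any group on the aromatic nitrogen, or any change to the shared core, gives a measurable value in this assay at all.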